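Swapping the aryl group on the triazole-linked terpenoid ester

A few compounds are considered here, and "the series" means these few. Any claim that something is new, unique, unknown or untested is made for them only; others in the source may bear on it.

Three esters of a shared core have been measured. In a functional assay on DU-145 cells (Homo sapiens) for antiproliferative activity, read by MTT assay, with a stated time of 48 h (a higher number here means a weaker inhibitor, a lower number a stronger inhibitor), compound 1 `C/C(=C\CC/C(C)=C/CC[C@@H]1[C@@]2(C)CCC(=O)C(C)(C)[C@H]2CC[C@@]1(C)O)CC/C=C(\C)C(=O)OCc1cn(-c2cccc(Cl)c2)nn1` gives 103000 nM. Compound 2 `C/C(=C\CC/C(C)=C/CC[C@@H]1[C@@]2(C)CCC(=O)C(C)(C)[C@H]2CC[C@@]1(C)O)CC/C=C(\C)C(=O)OCc1cn(-c2ccc(F)c(Cl)c2)nn1` reaches only the limit of the assay in this assay, > 150000 nM. Among the measured compounds shown here, the step of an at least 1.4-fold higher number from compound 1 to compound 2 (0.16 log units; that floor lies within the scatter) therefore rests on that limit, and its floor lies within the scatter; the only evidence on it is the limit of > 150000 nM in this assay, at which 1 of the 3 values shown sits. For the measured compounds named here, compound 3 `C/C(=C\CC/C(C)=C/CC[C@@H]1[C@@]2(C)CCC(=O)C(C)(C)[C@H]2CC[C@@]1(C)O)CC/C=C(\C)C(=O)OCc1cn(C[C@@H]2O[C@H](n3ccc(=O)[nH]c3=O)C[C@H]2O)nn1`, whose substituent on the ring nitrogen is a nucleoside rather than an aryl group, gives 33100 nM in this assay; no single-point step connects it to compound 1 or compound 2. Compound 2 thus stands at the weak end of what has been measured, as a limit rather than a number.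

Compound 4 `COc1ccccc1-n1cc(COC(=O)/C(C)=C/CC/C(C)=C/CC/C(C)=C/CC[C@@H]2[C@@]3(C)CCC(=O)C(C)(C)[C@H]3CC[C@@]2(C)O)nn1` has not yet been measured. It differs from compound 2 by 2-methoxyphenyl in place of 3-chloro-4-fluorophenyl on an aromatic nitrogen. Going by the values given here, no measured step involves a change of this kind: the one step known, from a hydrogen to a fluoro, is small and limit-bound, so it gives little guidance beyond indicating that aryl variation has so far moved activity only modestly. The step of an at least 1.3-fold lower number from compound 2 to compound 4 (0.13 log units; that floor lies within the scatter) is accordingly expected to be small or none beyond the scatter. Compound 4 is estimated to give 110000 nM in this assay, between 40000 nM and 300000 nM.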

Compound 4, half-maximal inhibitory concentration: > 150000 nM
Compound 4: a limit, no number; the forecaster's own chance of this, stated with the estimate: 35%; at least 1.3-fold (0.13 log units) between middle value and limit.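

Putting 2-methoxyphenyl on the aromatic nitrogen of the triazole, in place of 3-chloro-4-fluorophenyl, does not bring the series back from the limit in this assay; the result for compound 4 is again a limit and not a number. Set against compound 1, which has 3-chlorophenyl at this place, the change gives an at least 1.4-fold higher number from compound 1 to compound 4 (0.16 log units; that floor lies within the scatter), so it shows no loss beyond the scatter, and the step between the two compounds at the limit cannot be read. Two aryl groups that share no substituent, one carrying chlorine and fluorine and the other an oxygen with a hydrogen-bond acceptor, now end at the same limit, while compound 1 still gives a number, so the aryl groups shown do not yet order themselves along any single line: the limit of > 150000 nM in this assay, at which 2 of the 4 values shown sit.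

Left open is whether any aryl group at this place, for instance a phenyl ring bearing an amine or a carboxylic acid, would give a number clearly lower than that of compound 1. Also open, from the compounds shown here alone, is whether the value of compound 3, 33100 nM, is tied to its nucleoside or would be matched by a plain alkyl chain on the same nitrogen.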